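The compounds below may be only part of what the source reports. "The series", "measured", "known", "first", "only" and "open" are said of these compounds alone.

Measured compounds:
compound 1 `CC(C)c1onc(-c2c(Cl)cccc2Cl)c1COc1ccc(-c2ccc3cc(C(=O)O)cnc3c2)cc1` gives 260 nM
compound 2 `Cc1cc(OCc2c(-c3c(Cl)cccc3Cl)noc2C(C)C)ccc1-c1ccc2nc(C(=O)O)ccc2c1` gives 52 nM
compound 3 `COc1cc(C(=O)O)nc2ccc(-c3ccc(OCc4c(-c5c(Cl)cccc5Cl)noc4C(C)C)cc3)cc12` gives 17 nM

These three values come from a functional assay on CV-1 cells for agonist activity at Bile acid receptor (Homo sapiens), read by a luciferase reporter; a lower number here means that less compound is needed, a higher number that more compound is needed for the effect. Among them compound 3 has the lowest number; the nearest is compound 2, whose number is higher by a margin beyond the scatter, and the furthest is compound 1, higher still and well beyond the scatter. Compound 3 is therefore the most potent of the three measured compounds in this assay.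

The next compound, compound 4 `CC(C)COc1cc(C(=O)O)nc2ccc(-c3ccc(OCc4c(-c5c(Cl)cccc5Cl)noc4C(C)C)cc3)cc12`, differs from compound 3 in one place: isopropyl in place of hydrogen on a saturated chain carbon bound to an oxygen on an aromatic ring. Among the compounds with values here, no pair of measured compounds shows this kind of change, so nothing here tells how the assay responds to it; the expectation below rests only on the value of compound 3 and the size of the change.

The step from compound 3 to compound 4 is expected to be small, a 1.2-fold higher number from compound 3 to compound 4 (0.07 log units; within the scatter), with no clear direction beyond the scatter. Compound 4 is accordingly estimated at 20 nM, within a range from 6 nM to 70 nM.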

Compound 4, half-maximal effective concentration: 81 nM
The estimate for compound 4 lay 4.1-fold (0.61 log units) below the measured number; measured number above the stated range.
By their numbers in this assay, from the lowest: compound 3; then compounds 2 and 4 (each within the scatter of the next); then compound 1.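

Within the data shown here, changing methoxy to isobutoxy on the shared core gives a 4.8-fold higher number from compound 3 to compound 4 (0.68 log units; beyond the scatter) in this assay, the only single-place change that can be read in this set. It shows that this place responds to what is built onto the saturated chain carbon: with isopropyl in place of hydrogen there, agonist activity remains, but more compound is needed for the effect. Nothing shown accounts for this shift.

The compounds shown leave open whether the response follows chain length or branching, and an ethoxy or a straight butoxy group would separate the two. They also leave open how this place would respond to a chain ending in an amine or a hydroxyl group.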